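Dropping the ethynyl group from an anilinoquinazoline

The source may report more compounds than this note shows. Statements on the series, on what has been measured and on what is new or still open speak of the compounds shown alone.

Three compounds share one core and differ only in the aryl group attached to the amino nitrogen. In a functional assay on A-431 cells (Homo sapiens) for antiproliferative activity, read by MTT assay, with a stated time of 72 h (a lower number here means a stronger inhibitor, a higher number a weaker inhibitor), compound 1 `C#Cc1cccc(Nc2ncnc3cc(OC)c(OCCCCC(=O)Nc4ccc(S(N)(=O)=O)cc4)cc23)c1` gives 17700 nM, the second highest of the three numbers. Compound 2 `COc1cc2ncnc(Nc3ccc(Cl)cc3)c2cc1OCCCCC(=O)Nc1ccc(S(N)(=O)=O)cc1` gives 7120 nM, and compound 3 `COc1ccc(Nc2ncnc3cc(OC)c(OCCCCC(=O)Nc4ccc(S(N)(=O)=O)cc4)cc23)cc1OC` gives 35400 nM. The move a 2.5-fold lower number from compound 1 to compound 2 (0.40 log units; beyond the scatter) lies beyond the scatter, while a 2.0-fold higher number from compound 1 to compound 3 (0.30 log units; within the scatter) does not, and a 5.0-fold higher number from compound 2 to compound 3 (0.70 log units; beyond the scatter) is the widest gap among them.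

Compound 4 `COc1cc2ncnc(Nc3ccccc3)c2cc1OCCCCC(=O)Nc1ccc(S(N)(=O)=O)cc1` is the simplest member: hydrogen in place of ethynyl on an aromatic carbon. Going by the values given here, no measured step removes this group outright; the two steps starting from compound 1 only swap it for other groups, and they show that changing this ring shifts the number by modest amounts in either direction. A modest change is therefore expected here too, most likely toward a weaker inhibitor, as a 1.6-fold higher number from compound 1 to compound 4 (0.20 log units; within the scatter). Compound 4 is accordingly estimated at 28000 nM, within a range of 11000 nM to 70000 nM.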

Compound 4, half-maximal inhibitory concentration: 25200 nM
Compound 4: the middle estimate sits 1.1-fold (0.05 log units) above what was measured; the measured number falls inside the stated range.
By their numbers in this assay, from the lowest: compound 2; then compounds 1, 4 and 3 (each within the scatter of the next).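

In this assay the bare phenyl ring can now be set against each substituted ring, and removing ethynyl outright gives a 1.4-fold higher number from compound 1 to compound 4 (0.15 log units; within the scatter) and so no difference that can be read at this position. The 3,4-dimethoxyphenyl ring is no more distinct, with a 1.4-fold lower number from compound 3 to compound 4 (0.15 log units; within the scatter) as its step to phenyl. Only chloro separates from hydrogen, with a 3.5-fold higher number from compound 2 to compound 4 (0.55 log units; beyond the scatter) as the step, which sets compound 2 apart from the bare phenyl compound.

Still open, as far as these compounds go, is whether chloro would keep that edge on an aromatic carbon meta to a large group, where ethynyl sits in compound 1, and whether fluoro, bromo or trifluoromethyl in place of the chloro of compound 2 would do the same. Nothing measured here gives a reason for the chloro step.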